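The compounds below may be only part of what the source reports. "The series", "measured", "known", "first", "only" and "open" are said of these compounds alone.

Measured in a functional assay on HCT-116 cells (Homo sapiens), read by MTT assay, with a stated time of 72 h; on this read-out lower numbers stand for stronger inhibition and higher numbers for weaker inhibition:
Compound 1 `COc1nc(N)nc2c1c(-c1ccco1)cn2[C@@H]1O[C@H](CO)[C@@H](O)[C@H]1O`: > 20000 nM (a limit)
Compound 2 `COc1nc(N)nc2c1c(-c1ccoc1)cn2[C@@H]1O[C@H](CO)[C@@H](O)[C@H]1O`: > 20000 nM (a limit)

Compound 2 has no exact number in this assay: its > 20000 nM is a limit of the assay. Compound 1, with > 20000 nM, also stands at a limit. The evidence so far is therefore (the limit of > 20000 nM in this assay, at which 2 of the 2 values shown sit).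

Compound 3 `COc1nc(N)nc2c1c(-c1cccs1)cn2[C@@H]1O[C@H](CO)[C@@H](O)[C@H]1O` keeps the shared core and carries thiophen-2-yl in place of furan-3-yl on an aromatic carbon.

For the measured compounds named here, only one measured step bears on this change: a step that the two limits leave unreadable from compound 1 to compound 2. It exchanges one furan group for the other and gives no size to carry forward. Going by the values given here, neither furan compound left the limit, and no thiophene compound has yet been measured. The expectation therefore rests on (the limit of > 20000 nM in this assay, at which 2 of the 2 values shown sit), and no step beyond the usual scatter is expected, in either direction.

The estimated step is a step that the limit leaves unreadable from compound 2 to compound 3. For compound 3 the expected value is 25000 nM, with an estimated range of 8000 nM to 60000 nM. The assay may well report only a limit again.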

Compound 3, half-maximal inhibitory concentration: > 20000 nM
Compound 3: no number, only a limit (the forecaster's own chance of this, stated with the estimate: 80%); the middle value does not contradict the limit.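

Compound 3, like compound 1 and compound 2, gives only a limit in this assay, so no step among these three compounds can be read. All three stand at the same limit: the limit of > 20000 nM in this assay, at which 3 of the 3 values shown sit.

The compounds shown leave open whether the furan-2-yl, furan-3-yl and thiophen-2-yl groups differ at all in this assay's inhibition.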